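This account rests on a few compounds, and the source may have more. Where it says the series, first, only, none or still open, it means among the compounds named here.

Series on the shared core of compound 1 `CN(Cc1cccs1)C1CCN(CCCc2c[nH]c3ccc(-n4cnnc4)cc23)CC1`, assessed in an assay on CHO cells for displacement of a labelled ligand from 5-hydroxytryptamine receptor 1B (Homo sapiens); a higher number here means a weaker inhibitor, a lower number a stronger inhibitor. Compound 1 gives 140 nM, the second highest of the three numbers in hand. Compound 2 `CC(=O)Nc1ccc([C@H](C)NCC2CCN(CCCc3c[nH]c4ccc(-n5cnnc5)cc34)CC2)cc1` gives 9.3 nM in this assay, a lower number than compound 1 by a margin well beyond the scatter. Compound 3 `OC[C@H](NC1CCN(CCCc2c[nH]c3ccc(Cn4cncn4)cc23)CC1)c1ccccc1` gives 1300 nM, a higher number than compound 1, again beyond the scatter. Among the measured compounds shown here, neither compound 2 nor compound 3 differs from compound 1 in a single place, so no single-point step is available to read from.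

Compound 4 `CN(Cc1ccco1)C1CCN(CCCc2c[nH]c3ccc(-n4cnnc4)cc23)CC1` differs from compound 1 in one place: furan-2-yl in place of thiophen-2-yl on a saturated chain carbon bound to an amine nitrogen. The swap exchanges one five-membered aromatic ring with 1 hetero atom for another of the same description. With no measured step of this kind in the set, the step is expected to be small, a 1.1-fold higher number from compound 1 to compound 4 (0.06 log units; within the scatter), in no direction clearly beyond the scatter. Compound 4 is accordingly expected to give about 160 nM in this assay, with a range from 60 nM to 420 nM.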

Compound 4, half-maximal inhibitory concentration: 89 nM
Compound 4: middle estimate off by 1.8-fold (0.25 log units), on the high side; low and high end bracket the measured number.
By their numbers in this assay, from the lowest: compound 2; then compounds 4 and 1 (each within the scatter of the next); then compound 3.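

In this assay, furan-2-yl in place of thiophen-2-yl on a saturated chain carbon bound to an amine nitrogen gives a 1.6-fold lower number from compound 1 to compound 4 (0.20 log units; within the scatter), the first single-place step available in the series. At this position, one five-membered aromatic ring with 1 hetero atom can therefore stand in for another, with oxygen replacing sulfur, without a shift that can be told from the scatter. No measurement in hand offers an explanation for this result.

From the compounds shown here alone, both rings are of the same description, so it remains open how this position responds to a phenyl ring, a pyridine ring, a saturated ring such as tetrahydrofuran, or a plain alkyl chain. The methyl group on the amine nitrogen is also untested as a point of change, for example against a hydrogen or an ethyl group.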